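The compounds below may be only part of what the source reports. "The series", "measured", "known", "first", "only" and "open" are said of these compounds alone.

Measured in an ADME assay (liver) for metabolic stability, with Liver microsome (Canis lupus familiaris) as the target, read by LC-MS, using microsomes, with a stated time of 30 min, tested at 4 uM; a higher number here means that more of the compound is left, a lower number that less of the compound is left:
Compound 1 `CCN1CCN(c2nc(C)nc3c2nc(-c2ccccc2Cl)n3CCOC)CC1`: 86%
Compound 2 `Cc1nc(N2CCN(C)CC2)c2nc(-c3cccc(Cl)c3)n(C3CCOCC3)c2n1`: 45%

Of the two, compound 2 stands lowest at 45%, while compound 1, at 86%, lies above it by more than the usual scatter. Compound 3 `COc1ccccc1-c1nc2c(N3CCN(C)CC3)nc(C)nc2n1C1CCOCC1` has not yet been measured. It arises from compound 2 through a single change: 2-methoxyphenyl in place of 3-chlorophenyl on an aromatic carbon. For the measured compounds named here, no pair of measured compounds differs in only one place, so the data offer no direct precedent for this change in this assay. The gap between compound 1 and compound 2 cannot be assigned to any one difference. A small upward step is therefore expected, quite possibly none beyond the scatter. The expected change is a number 5 percentage points higher from compound 2 to compound 3 (within the scatter). For compound 3, the estimated value is 50%, with an expected range of 28% to 72%.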

Compound 3, percent of the compound remaining: 36%
Compound 3: middle estimate off by 14 percentage points, on the high side; measured number inside the range.
By their numbers in this assay, from the lowest: compounds 3 and 2 (each within the scatter of the next); then compound 1.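

In this assay, the aromatic carbon between two ring nitrogen atoms now has its first comparison that differs in one place: 2-methoxyphenyl in place of 3-chlorophenyl gives a number 9 percentage points lower from compound 2 to compound 3 (within the scatter). With the oxan-4-yl group held constant, exchanging these two aryl groups, although it brings in an oxygen and a hydrogen-bond acceptor, therefore does not shift the read-out beyond the scatter. Nothing available explains this outcome or links it to a property of either group.

Going by these compounds, whether an unsubstituted phenyl or a pyridyl group at this carbon would fall outside the scatter of these two compounds remains open. So does what 2-chlorophenyl would give alongside the oxan-4-yl group, since it appears only in compound 1, which differs from these compounds in more than one place.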